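This account rests on a few compounds, and the source may have more. Where it says the series, first, only, none or still open, it means among the compounds named here.

Compound 1, `CCCCCCCN1CCC(C(=O)Nc2cc(Cl)c(N)cc2OC)CC1`: > 10 mg/kg
Compound 2, `COc1cc(N)c(Cl)cc1NC(=O)C1CCN(CC2CC2)CC1`: > 10 mg/kg
Compound 3, `COc1cc(N)c(Cl)cc1NC(=O)C1CCN(Cc2ccc(F)cc2)CC1`: 0.6 mg/kg

In a functional assay on the whole organism for antagonist activity, with Mus musculus as the target (a lower number here means that less compound is needed, a higher number that more compound is needed for the effect), compound 1 reaches only a limit of the assay, > 10 mg/kg. Compound 2 likewise reaches only a limit, > 10 mg/kg. Within the data shown here, compound 3 gives a number, 0.6 mg/kg, and it is the only number among the three, the other two sitting at the limit of > 10 mg/kg in this assay, at which 2 of the 3 values shown sit. The steps of an at least 16-fold lower number from compound 1 to compound 3 (1.22 log units; beyond the scatter) and an at least 16-fold lower number from compound 2 to compound 3 (1.22 log units; beyond the scatter) each put 4-fluorophenyl on the saturated chain carbon bound to an amine nitrogen in a ring, whereas a step that the two limits leave unreadable from compound 1 to compound 2 cannot be read.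

Compound 4, `COc1cc(N)c(Cl)cc1NC(=O)C1CCN(Cc2ccc([N+](=O)[O-])cc2)CC1`, keeps that 4-fluorophenyl arrangement except for one change on the aromatic carbon of the six-membered aromatic ring of carbon only: nitro in place of fluoro on an aromatic carbon. Among the measured compounds shown here, none of the measured steps alters a group on this ring, so they offer no direct guide; they show only that the compound carrying 4-fluorophenyl is the one that yields a number. A step within the usual scatter is therefore expected, a 1.7-fold higher number from compound 3 to compound 4 (0.22 log units; within the scatter). Compound 4 is estimated at 1 mg/kg, with a range from 0.3 mg/kg to 3 mg/kg.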

Compound 4, dose for half-maximal effect: > 4 mg/kg
Compound 4 ended at the assay's limit; the forecaster's own chance of this, stated with the estimate: 15%; middle value at least 4.0-fold (0.60 log units) away from the limit.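

Among these compounds, until now, no step had changed anything on this aromatic ring. In this assay, nitro in place of fluoro on the aromatic carbon para to a large group gives an at least 6.6-fold higher number from compound 3 to compound 4 (0.82 log units; beyond the scatter), so what sits at this place matters, and 4-nitrophenyl does not match 4-fluorophenyl. Compound 4 gives no number, only a limit of the assay, so that step is a minimum and the steps from compound 1 and from compound 2 to compound 4 cannot be read: the limit of > 4 mg/kg in this assay, at which 1 of the 4 values shown sits.

From the compounds shown here alone, how far the true value of compound 4 lies from its limit stays open. Going by these compounds, it is also open whether fluoro is special here or whether chloro, methoxy or an amine at this place would give a number like that of compound 3.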